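Removing the methoxy group of compound 3: an expectation

The source may hold more compounds than are shown below. What is called first, only, known or untested is meant among the compounds shown, and "the series" means these compounds.

Of the compounds shown here, three sharing one core have been measured in a functional assay on U-87MG ATCC cells for antiproliferative activity against U-87 MG (Homo sapiens), read by MTT assay, with a stated time of 48 h, tested at 5 uM; on this read-out lower numbers stand for a stronger effect and higher numbers for a weaker effect at the one concentration tested. Compound 1 `COc1ccc(-c2nc(SCC(=O)c3sc(-c4ccccc4)nc3C)nc(N)c2C#N)cc1` gives 68.8%, compound 2 `COc1ccc(-c2nc(C)c(C(=O)CSc3nc(N)c(C#N)c(-c4ccc(Cl)cc4)n3)s2)cc1` gives 51.4%, and compound 3 `COc1ccc(-c2nc(C)c(C(=O)CSc3nc(N)c(C#N)c(-c4ccccc4)n3)s2)cc1` gives 61.8%. Among the measured compounds shown here, compound 3 stands second highest of the three; its distance to compound 1 lies within the scatter, whereas the single one-place step, a number 10.4 percentage points higher from compound 2 to compound 3 (beyond the scatter), lies beyond it.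

Compound 4 `Cc1nc(-c2ccccc2)sc1C(=O)CSc1nc(N)c(C#N)c(-c2ccccc2)n1` differs from compound 3 in one place: hydrogen in place of methoxy on an aromatic carbon. For the measured compounds named here, no measured step concerns a methoxy group; the only measured step, from compound 2 to compound 3, concerns a chloro on the other ring and was modest. The values of compound 1 and compound 3, which carry the methoxy group on different rings, lie within the scatter of each other, so the data give no ground for a directional step. Compound 4 is therefore expected to show a number 2.2 percentage points higher from compound 3 to compound 4 (within the scatter), a change not beyond the scatter. The estimate for compound 4 in this assay is 64%, in a range from 50% to 78%.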

Compound 4, a percentage reported as activity, at one concentration (the size of the read-out at that concentration, not a potency): 103%
Compound 4: middle estimate off by 39 percentage points, on the low side; measured number outside the range, above it.
By their numbers in this assay, from the lowest: compound 2; then compounds 3 and 1 (each within the scatter of the next); then compound 4.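

In this assay, the change from 4-methoxyphenyl to phenyl goes with a number 41.2 percentage points higher from compound 3 to compound 4 (beyond the scatter), and the same change on the other ring goes with a number 34.2 percentage points higher from compound 1 to compound 4 (beyond the scatter). The earlier compounds shown here all carried a methoxy group and gave no step for it, whereas compound 4 carries none and shows that, at the one concentration tested, the effect depends heavily on having a methoxy group on one ring or the other. Nothing measured here accounts for the size of these steps.

Going by these compounds, whether a smaller or different group at this place, such as a fluoro, a hydroxyl or a dimethylamino group, would retain the effect remains open. So does whether a longer ether such as ethoxy would match methoxy, and whether methoxy groups on both rings together would strengthen it.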